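The compounds below may be only part of what the source reports. "The series", "measured", "known", "first", "only" and "open" are said of these compounds alone.

Compound 1 `CC(C)[C@H](NC(=O)COc1cccc2ccccc12)C(=O)N[C@@H](CC(=O)O)C(=O)COC(=O)c1c(Cl)cccc1Cl` carries a (2,6-dichlorophenyl)carbonyl on an oxygen on a saturated carbon; in a functional assay on Jurkat cells (Homo sapiens) (on this read-out higher numbers stand for weaker inhibition and lower numbers for stronger inhibition), compound 1 gives 10600 nM. Compound 2 `CC(C)[C@H](NC(=O)COc1cccc2ccccc12)C(=O)N[C@@H](CC(=O)O)C(=O)COc1ccccc1C(F)(F)F` puts 2-(trifluoromethyl)phenyl in place of that group. In this assay compound 2 reaches only > 100000 nM, which is a limit of the assay and not a number. For the measured compounds named here, that move is an at least 9.4-fold higher number from compound 1 to compound 2 (0.97 log units; beyond the scatter), so compound 2 stands at the weak end of the two values shown, with the limit of > 100000 nM in this assay, at which 1 of the 2 values shown sits, as the only information on it. Compound 3 `CC(C)[C@H](NC(=O)COc1cccc2ccccc12)C(=O)N[C@@H](CC(=O)O)C(=O)COc1ccccc1[N+](=O)[O-]` differs from compound 2 by nitro in place of trifluoromethyl on an aromatic carbon. Going by the values given here, no measured step covers this exchange; the single step known concerns the group on the oxygen on the saturated carbon, not a group on an aromatic carbon. With compound 2 at a limit, the step of a number no higher from compound 2 to compound 3 (the limit leaves the size open) is expected to stay near that limit, with no direction beyond the scatter claimed. Compound 3 is estimated at 100000 nM in this assay, between 30000 nM and 400000 nM.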

Compound 3, half-maximal inhibitory concentration: > 100000 nM
Compound 3: no number, only a limit; the forecaster's own chance of this, stated with the estimate: 60%; the middle value sits exactly at the limit.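

In this assay compound 3 gives > 100000 nM, which is a limit of the assay and not a number. Putting 2-nitrophenyl in place of (2,6-dichlorophenyl)carbonyl on the oxygen on a saturated carbon gives an at least 9.4-fold higher number from compound 1 to compound 3 (0.97 log units; beyond the scatter), so the reading seen with 2-(trifluoromethyl)phenyl on that oxygen is not confined to trifluoromethyl. The step between the two compounds at the limit cannot be read, so nitro and trifluoromethyl on this aromatic carbon cannot be ranked against each other: the limit of > 100000 nM in this assay, at which 2 of the 3 values shown sit.

Open, from the compounds shown here alone, is whether an amine or a carboxylic acid on that aromatic carbon would give a readable number. Also open, going by these compounds, is whether an unsubstituted benzoyl group on the oxygen would stay near compound 1 or reach the limit.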